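Butyl to pent-1-en-1-yl on a carbonyl carbon

The compounds below may be only part of what the source reports. "The series", "measured", "known", "first", "only" and "open" are said of these compounds alone.

Among the measured compounds shown here, in a functional assay on KYSE-450 cells (Homo sapiens) for inhibition, read by MTT assay, with a stated time of 48 h (a lower number here means a stronger inhibitor, a higher number a weaker inhibitor), compound 1 `CCCCC(=O)N(Cc1ccc(OC)c(O)c1)c1cc(OC)c(OC)c(OC)c1` reads 300 nM and holds the lowest of the three numbers so far, with both others beyond the scatter from it. Compound 2 `C/C=C/C(=O)N(Cc1ccc(OC)c(OC)c1)c1cc(OC)c(OC)c(OC)c1` gives 39100 nM in that test, and compound 3 `COc1ccc(CNc2cc(OC)c(OC)c(OC)c2)cc1Br` gives 39800 nM in that test.

Compound 4 `CCC/C=C/C(=O)N(Cc1ccc(OC)c(O)c1)c1cc(OC)c(OC)c(OC)c1` keeps the core of compound 1 and changes one place. The change, (pent-1-en-1-yl in place of butyl on a carbonyl carbon), puts pent-1-en-1-yl in place of butyl on a carbonyl carbon whose other neighbour is an amide-type nitrogen.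

No measured pair in the series differs in one place, so the size of this change is not shown directly. With compound 1 at 300 nM as the only anchor, a modest move toward a higher number is expected in this assay for this change. The estimated step of a 1.7-fold higher number from compound 1 to compound 4 (0.22 log units; within the scatter) is expected to stay small and may not clear the scatter. For compound 4 the estimated value is 500 nM with an expected range of 100 nM to 4000 nM in this series.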

Compound 4, half-maximal inhibitory concentration: 57 nM
Beside the measured number, compound 4's estimate is 8.8-fold (0.94 log units) above it; measured number below the stated range.
By their numbers in this assay, from the lowest: compound 4; then compound 1; then compounds 2 and 3 (each within the scatter of the next).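

Among the compounds shown here, at the carbonyl carbon whose other neighbour is an amide-type nitrogen, the chain is not a silent feature in this assay: pent-1-en-1-yl in place of butyl gives a 5.3-fold lower number from compound 1 to compound 4 (0.72 log units; beyond the scatter) on the core of compound 1, the only single-place step so far and one that clears the scatter. This step shows that the position accepts the longer chain with its double bond and that the read-out responds to what sits there, but the added carbon and the double bond enter together and cannot be told apart. The data on hand offer no measurement that bears on the reason for this step.

Saturated pentyl at the same carbon would separate the two contributions. Going by these compounds, whether a longer chain such as hept-1-en-1-yl, or a phenyl group, continues the move toward lower numbers remains open.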